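Working notes on cytotoxicity: from compound 1 to compound 3

The source may report more compounds than this note shows. Statements on the series, on what has been measured and on what is new or still open speak of the compounds shown alone.

Measured so far in an ADME assay on Vero cells (Chlorocebus sabaeus) for cytotoxicity, read by resazurin assay, with a stated time of 3 days; on this read-out higher numbers stand for weaker inhibition and lower numbers for stronger inhibition:
- compound 1 `CCN(CC)c1cc2[nH]c(C3CCCCC3)nc2cc1NC(=O)OCCOCCOC`: > 100 ug/mL
- compound 2 `Cc1ccc(C(=O)Nc2cc3nc(C4CCCCC4)[nH]c3cc2N(C)C)cc1`: > 100 ug/mL

Neither of these values is a number. Compound 1 sits at the limit of this assay with > 100 ug/mL. Compound 2 also sits at a limit there, > 100 ug/mL. Among the measured compounds shown here, compound 1 therefore stands at the top of what the read-out reports, and the only other value shown stands at the same place: the limit of > 100 ug/mL in this assay, at which 2 of the 2 values shown sit. For the measured compounds named here, no pair of measured compounds differs in a single place, so no measured step is available.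

Compound 3 `CCCCNC(=O)Nc1cc2nc(C3CCCCC3)[nH]c2cc1N(CC)CC` differs from compound 1 by butylamino in place of 2-(2-methoxyethoxy)ethoxy on a carbonyl carbon. With both measured values at the same limit, no step beyond the scatter is expected in this assay in either direction. Compound 3 is therefore expected to stay at the limit too, estimated at 100 ug/mL with a range from 50 ug/mL to 200 ug/mL. This expected step amounts to a number no higher from compound 1 to compound 3 (the limit leaves the size open).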

Compound 3, half-maximal inhibitory concentration: > 100 ug/mL
Compound 3 was reported as a limit; the forecaster's own chance of this, stated with the estimate: 75%; the middle value lies on the limit itself.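

Compound 1 and compound 3 both report only a limit, not a number, so no step can be read between them: the limit of > 100 ug/mL in this assay, at which 3 of the 3 values shown sit.

The compounds shown leave open whether butylamino or 2-(2-methoxyethoxy)ethoxy on a carbonyl carbon makes any difference in this assay.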